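One aryl swap on a shared core

A few compounds are considered here, and "the series" means these few. Any claim that something is new, unique, unknown or untested is made for them only; others in the source may bear on it.

Compound 3 `COc1cc(NC(=O)Nc2cc(Nc3cc(I)ccc3OC)ncn2)cc(OC)c1` gives 91% in a functional assay on PC-9 cells (Homo sapiens) for inhibition, read by MTT assay, with a stated time of 48 h, tested at 10 uM (on this read-out lower numbers stand for less inhibition and higher numbers for more inhibition at the one concentration tested (going by the name of the read-out)), the highest of the three numbers at hand. Compound 2 `CCc1cccc(Nc2cc(NC(=O)Nc3cc(OC)cc(OC)c3)ncn2)c1` gives 82.1%, and compound 1 `COc1cc(NC(=O)Nc2cc(Nc3ccc(C)c(F)c3)ncn2)cc(OC)c1` gives 77.5%. The step of a number 8.9 percentage points higher from compound 2 to compound 3 (within the scatter) stays within the scatter, whereas the step of a number 13.5 percentage points higher from compound 1 to compound 3 (beyond the scatter) goes beyond it, so compound 3 stands clearly above compound 1 only.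

Compound 4 `COc1cc(NC(=O)Nc2cc(Nc3cc(C)cc(F)c3)ncn2)cc(OC)c1` has not yet been measured. It differs from compound 3 in one place: 3-fluoro-5-methylphenyl in place of 5-iodo-2-methoxyphenyl on a nitrogen on an aromatic ring. The group that enters closely resembles the 3-fluoro-4-methylphenyl of compound 1, so the step of a number 13.5 percentage points higher from compound 1 to compound 3 (beyond the scatter) bears most directly on this change, and the step of a number 8.9 percentage points higher from compound 2 to compound 3 (within the scatter) points the same way, if more weakly. Undoing a change of this kind is therefore expected to lower the read-out modestly, the expected step being a number 13 percentage points lower from compound 3 to compound 4 (beyond the scatter). Compound 4 is accordingly estimated at 78% in this assay, with an expected range from 65% to 90%.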

Compound 4, a percentage reported as inhibition, at one concentration (the size of the read-out at that concentration, not a potency): 64.5%
Compound 4: middle estimate off by 13.5 percentage points, on the high side; measured number outside the range, below it.
By their numbers in this assay, from the lowest: compound 4; then compounds 1, 2 and 3 (each within the scatter of the next, the first and the last beyond it).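

The step of a number 13 percentage points lower from compound 1 to compound 4 (beyond the scatter) shows that this position is sensitive to more than which substituents are present: 3-fluoro-4-methylphenyl and 3-fluoro-5-methylphenyl carry the same fluorine and methyl and differ only in the position number of the methyl. Compound 4 also falls clearly short of the other two aryl groups, with a number 17.6 percentage points lower from compound 2 to compound 4 (beyond the scatter) and a number 26.5 percentage points lower from compound 3 to compound 4 (beyond the scatter) in the same assay. The group on this nitrogen therefore spans a wider range of this assay than the first three compounds showed, and compound 4 now marks its low end among the four.

Nothing at hand explains why the read-out moves with these groups. Also open, from the compounds shown here alone, is how an amine, a carboxylic acid or a longer chain on this aryl ring would fare.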